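This account rests on a few compounds, and the source may have more. Where it says the series, first, only, none or still open, it means among the compounds named here.

Compound 2 `CC1CCCCC1N(C(=O)c1cc(C2CC2)on1)C1CCCCC1` is the starting point here. In an assay on isolated protein for agonist activity at sphingosine 1-phosphate receptor 4 (Homo sapiens) (on this read-out higher numbers stand for an effect only at larger amounts of compound and lower numbers for an effect already at smaller amounts), compound 2 gives > 50000 nM, which is a limit of the assay rather than a number. Compound 1 `CC1CCCCC1N(C(=O)c1cc(C2CC2)on1)C1CCCCC1C` in this assay gives > 50000 nM, likewise a limit. Among the measured compounds shown here, the one measured step, a step that the two limits leave unreadable from compound 1 to compound 2, therefore cannot be read, and both values rest at the limit of > 50000 nM in this assay, at which 2 of the 2 values shown sit. Compound 3 `CC1CCCCC1N(C(=O)c1cc(C2CC2)on1)C1CCCCCC1` carries cycloheptyl in place of cyclohexyl on an amide-type nitrogen. No readable measured step bears on this change, so nothing beyond the usual scatter is expected. Compound 3 is estimated at 50000 nM, within 20000 nM to 100000 nM, most likely again as a limit. The step of a number no higher from compound 2 to compound 3 (the limit leaves the size open) is thus expected to be essentially none.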

Compound 3, half-maximal effective concentration: > 50000 nM
Compound 3 ended at the assay's limit; the forecaster's own chance of this, stated with the estimate: 85%; the middle value sits exactly at the limit.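

No step can be read between compound 1, compound 2 and compound 3, since all three values are limits and not numbers: the limit of > 50000 nM in this assay, at which 3 of the 3 values shown sit.

In this assay the compounds shown leave open whether any group on the amide-type nitrogen gives a readable value.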